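Ring swap on the central chain carbon across two cores

The source may report more compounds than this note shows. Statements on the series, on what has been measured and on what is new or still open speak of the compounds shown alone.

Measured in a functional assay on MCF7 cells (Homo sapiens) for antiproliferative activity, read by sulforhodamine B assay, with a stated time of 48 h; a lower number here means a stronger inhibitor, a higher number a weaker inhibitor:
compound 1 `COc1ccc(OC)c(/C=C/C(=O)C(=Cc2cc(OC)c(O)c(OC)c2)C(=O)/C=C/c2cc(OC)ccc2OC)c1` gives 430 nM
compound 2 `COc1ccc(OC)c(/C=C/C(=O)C(=Cc2ccc(OC)c(O)c2)C(=O)/C=C/c2cc(OC)ccc2OC)c1` gives 990 nM
compound 3 `COc1ccc(/C=C/C(=O)C(=Cc2cc(OC)c(O)c(OC)c2)C(=O)/C=C/c2ccc(OC)cc2OC)c(OC)c1` gives 970 nM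

Compound 1 and compound 3 are built from the same atoms joined differently; the difference between the two cores is not broken down here. Their values in this assay are 430 nM for compound 1 and 970 nM for compound 3, a gap beyond the scatter. Compound 2 and compound 3 sit within the scatter of each other.

Within the core of compound 1, the change 3-hydroxy-4-methoxyphenyl in place of 4-hydroxy-3,5-dimethoxyphenyl on a double-bonded chain carbon bound to a double-bonded chain carbon gives a 2.3-fold higher number from compound 1 to compound 2 (0.36 log units; beyond the scatter).

Compound 4 `COc1ccc(/C=C/C(=O)C(=Cc2ccc(OC)c(O)c2)C(=O)/C=C/c2ccc(OC)cc2OC)c(OC)c1` is not yet measured. It differs from compound 3 by 3-hydroxy-4-methoxyphenyl in place of 4-hydroxy-3,5-dimethoxyphenyl on a double-bonded chain carbon bound to a double-bonded chain carbon, the same change made from compound 1 to compound 2 on the other core; it occurs twice among these compounds. The place is described in the same words for both pairs.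

Among the measured compounds shown here, compound 4 is expected to show a 2.3-fold higher number from compound 3 to compound 4 (0.36 log units; beyond the scatter), a step of about the size seen in a 2.3-fold higher number from compound 1 to compound 2 (0.36 log units; beyond the scatter), since this is the single measured instance of the change and the two cores cannot be compared further here. The estimate for compound 4 is therefore 2200 nM, between 1200 nM and 4500 nM.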

Compound 4, half-maximal inhibitory concentration: 1600 nM
For compound 4 the middle estimate is 1.4-fold (0.14 log units) above the measured one; low and high end bracket the measured number.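

In this assay, 3-hydroxy-4-methoxyphenyl in place of 4-hydroxy-3,5-dimethoxyphenyl on the second core gives a 1.6-fold higher number from compound 3 to compound 4 (0.22 log units; within the scatter), so on this core the step alone cannot be told apart from repeat-measurement noise. Even so, the two steps do not differ from each other, and the change carries from one core to the other as far as these pairs can tell: the same change on two cores in this assay, a 2.3-fold higher number (0.36 log units; beyond the scatter) from compound 1 to compound 2 and a 1.6-fold higher number (0.22 log units; within the scatter) from compound 3 to compound 4, 1.4-fold (0.14 log units) apart, within the scatter of two such steps

This rests on just two pairs, one of them within the scatter, so it does not establish a real effect of the change on the second core, nor that the change would behave alike on any further core, and it gives no reason for the result.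

Still open, on these data alone, is how a phenyl ring carrying an amine or a carboxylic acid would fare on a double-bonded chain carbon bound to a double-bonded chain carbon, on either core. Also open, as far as these compounds go, is which feature of the two cores separates them, since that difference is not broken down by these compounds.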